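A halophenyl swap on a shared core

The source may hold more compounds than are shown below. What is called first, only, known or untested is meant among the compounds shown, and "the series" means these compounds.

Compound 1 `COc1cc(-c2ncnn2-c2ccc(Cl)c(Cl)c2)cc(OC)c1OC` carries a 3,4-dichlorophenyl group on its core. In a functional assay on MCF7 cells (Homo sapiens) for antiproliferative activity, read by MTT assay, with a stated time of 72 h (on this read-out lower numbers stand for stronger inhibition and higher numbers for weaker inhibition), compound 1 gives > 10000 nM, which is a limit of the assay rather than a number. Compound 2 `COc1cc(-n2ncnc2-c2ccccc2)cc(OC)c1OC` is the other measured member of the set. In this assay compound 2 gives > 10000 nM, again a limit and not a number. For the measured compounds named here, compound 1 therefore stands at the edge of what this read-out resolves: the limit of > 10000 nM in this assay, at which 2 of the 2 values shown sit, so no measured step between compounds can be drawn, and neither measured compound can be called more or less active than the other.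

Compound 3 `COc1cc(-c2ncnn2-c2cccc(F)c2)cc(OC)c1OC` is not yet measured. It differs from compound 1 in one place: 3-fluorophenyl in place of 3,4-dichlorophenyl on an aromatic nitrogen. Going by the values given here, with both measured values sitting at the limit, there is no measured step on which to base a direction, so the expectation for compound 3 is a step that the limit leaves unreadable from compound 1 to compound 3 of no size beyond the scatter, most likely ending again at the limit. Compound 3 is accordingly estimated at 15000 nM, within a range of 5000 nM to 50000 nM.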

Compound 3, half-maximal inhibitory concentration: > 10000 nM
Compound 3 gave a limit, no number (the forecaster's own chance of this, stated with the estimate: 75%); the middle value is on the limit's open side.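

In this assay compound 3 gives > 10000 nM, a limit of the assay and not a number. No step between compound 1 and compound 3 can be read, and all three compounds sit at the same edge: the limit of > 10000 nM in this assay, at which 3 of the 3 values shown sit.

The compounds shown leave open which changes to the shared core, if any, would give a measurable value.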